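Cytotoxicity Readout for a Dichlorophenyl Analogue

The compounds below may be only part of what the source reports. "The series", "measured", "known", "first", "only" and "open" are said of these compounds alone.

Compound 1 `CCOC(=O)CCCCCOc1cccc(CN(C(=O)c2ccc(-c3ccoc3)cc2)C(C)C)c1` gives > 26000 nM in an ADME assay on Raji cells (Homo sapiens) for cytotoxicity, read by CellTiter-Glo and resazurin assay, with a stated time of 72 h (on this read-out lower numbers stand for an effect already at smaller amounts and higher numbers for an effect only at larger amounts of compound), a limit of the assay rather than a number. Compound 2 `CCOC(=O)CCCCCOc1cccc(CN(C(=O)c2ccc(-c3cccc(OC)c3)cc2)C(C)C)c1` gives > 21000 nM in this assay, again a limit. Compound 3 `CCOC(=O)CCCCCOc1cccc(CN(C(=O)c2ccc(-c3ccc4cc[nH]c4c3)cc2)C(C)C)c1` gives > 26000 nM in this assay, also a limit.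

Compound 3 therefore stands only at a limit, and the two other values shown are limits as well, as the limit of > 21000 nM in this assay, at which 1 of the 3 values shown sits, and the limit of > 26000 nM in this assay, at which 2 of the 3 values shown sit, record. The steps a step that the two limits leave unreadable from compound 1 to compound 2, a step that the two limits leave unreadable from compound 1 to compound 3 and a step that the two limits leave unreadable from compound 2 to compound 3 are all left unreadable by these limits, so no size can be taken from them.

Compound 4 `CCOC(=O)CCCCCOc1cccc(CN(C(=O)c2ccc(-c3ccc(Cl)c(Cl)c3)cc2)C(C)C)c1` differs from compound 3 by 3,4-dichlorophenyl in place of 1H-indol-6-yl on an aromatic carbon. Within the data shown here, no measured step bears on this change with a readable size, since every value shown is a limit. Among the measured compounds shown here, the only guide is that all three measured compounds sit at limits, so no step beyond the scatter is expected in this assay in either direction.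

Compound 4 is thus expected to give about 26000 nM, estimated within 8000 nM to 30000 nM. The step of a number no higher from compound 3 to compound 4 (the limit leaves the size open) is expected to stay within the scatter, most likely as another limit.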

Compound 4, half-maximal effective concentration: > 26000 nM
Compound 4 was reported as a limit; the forecaster's own chance of this, stated with the estimate: 70%; the middle value lies on the limit itself.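

Compound 4 gives > 26000 nM in this assay, which is a limit and not a number. Compound 1, compound 2 and compound 3 also stand at limits, so none of their steps to compound 4 can be read. The compounds shown leave open what concentration, if any, of these four compounds would produce a half-maximal cytotoxic effect on these cells.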